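Morpholine Amide Series: Substitution at the Amine

The source may report more compounds than this note shows. Statements on the series, on what has been measured and on what is new or still open speak of the compounds shown alone.

Compound 2 `CNc1nc(Cl)nc2c1ncn2[C@@H]1O[C@H](C(=O)N2CCOCC2)[C@@H](O)[C@H]1O` is the weaker of the two measured compounds: in an assay on CHO cells for displacement of a labelled ligand from adenosine receptor A3 (Homo sapiens) (a higher number here means a weaker inhibitor, a lower number a stronger inhibitor), compound 2 gives 3890 nM, whereas compound 1 `CNc1nc(Cl)nc2c1ncn2[C@@H]1O[C@H](C(=O)NCC2CC2)[C@@H](O)[C@H]1O` gives 1.1 nM. Among the measured compounds shown here, the only measured step, a 3500-fold higher number from compound 1 to compound 2 (3.55 log units; beyond the scatter), concerns the amide substituent and not the amine on the core. Compound 3 `Cc1ccccc1CNc1nc(Cl)nc2c1ncn2[C@@H]1O[C@H](C(=O)N2CCOCC2)[C@@H](O)[C@H]1O` differs from compound 2 by 2-methylphenyl in place of hydrogen on a saturated chain carbon bound to a nitrogen on an aromatic ring. For the measured compounds named here, no measured step bears on this change; the single recorded step sits on the carbonyl side of the molecule, so its size gives no guide to the amine side. The direction and size of the step in this assay are therefore open, and the estimate for compound 3 is placed near the value of compound 2 with a wide range, expected at 2000 nM (from 150 nM to 15000 nM), corresponding to an expected step of a 1.9-fold lower number from compound 2 to compound 3 (0.29 log units; within the scatter).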

Compound 3, inhibition constant: 7590 nM
Beside the measured number, compound 3's estimate is 3.8-fold (0.58 log units) below it; low and high end bracket the measured number.
By their numbers in this assay, from the lowest: compound 1; then compounds 2 and 3 (each within the scatter of the next).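

In this assay, 2-methylphenyl in place of hydrogen on a saturated chain carbon bound to a nitrogen on an aromatic ring, which turns methylamino into (2-methylbenzyl)amino, gives a 2.0-fold higher number from compound 2 to compound 3 (0.29 log units; within the scatter). Among the compounds shown here, this is the first reading on the amine side of the series, and with the morpholine amide in place the larger substituent leaves the two numbers indistinguishable. That step is small beside a 3500-fold higher number from compound 1 to compound 2 (3.55 log units; beyond the scatter) on the carbonyl side, but with the weak morpholine amide as background it says little about how the position behaves in a strong compound.

As far as these compounds go, whether (2-methylbenzyl)amino reads the same with the (cyclopropylmethyl)amino carbonyl of compound 1 remains open. So does the effect of an unsubstituted benzyl or a longer alkyl chain on this amine. No measured data bearing on the reason for this result are available.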